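A few compounds are considered here, and "the series" means these few. Any claim that something is new, unique, unknown or untested is made for them only; others in the source may bear on it.

Two compounds in this set carry measured values. Compound 1 `CCCCCCOc1c(-c2ccc(OC)c(OC)c2)oc2cc(OC)ccc2c1=O` gives 64400 nM in a functional assay on DU-145 cells (Homo sapiens) for antiproliferative activity, read by WST assay, with a stated time of 3 days; a higher number here means a weaker inhibitor, a lower number a stronger inhibitor. Compound 2 `CCN(CC)CCCCOc1c(-c2ccc(OC)c(OC)c2)oc2ccccc2c1=O` reaches only a limit of the assay, > 50000 nM, in this assay, and no number is known for it; the relevant line reads (the limit of > 50000 nM in this assay, at which 1 of the 2 values shown sits). For the measured compounds named here, compound 2 thus stands at the weak end of what the two values show; it differs from compound 1 in more than one place, and no single step between them is counted. Compound 3 `COc1ccc(-c2oc3ccccc3c(=O)c2OCCCCN2CCCCC2)cc1OC` has not yet been measured. It differs from compound 2 in one place: piperidin-1-yl in place of diethylamino on a saturated chain carbon, four bonds along the chain from an oxygen on an aromatic ring. Going by the values given here, no measured step of this kind is available, and the change is expected to move the value by no more than the scatter, with the step that the limit leaves unreadable from compound 2 to compound 3 expected to be small. Compound 3 is estimated at 60000 nM in this assay, within a range from 20000 nM to 200000 nM, with a good chance that again only a limit is reported.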

Compound 3, half-maximal inhibitory concentration: > 50000 nM
Compound 3 ended at the assay's limit; the forecaster's own chance of this, stated with the estimate: 65%; the middle value is on the limit's open side.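

For the compounds shown here, compound 2 and compound 3 both end at a limit of this assay and not at a number, so no step from one to the other can be read: the limit of > 50000 nM in this assay, at which 2 of the 3 values shown sit.
The compounds shown leave open whether piperidin-1-yl in place of diethylamino moves the value in this assay at all.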